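The compounds below may be only part of what the source reports. "The series", "measured", "known", "first", "only" and "open" are said of these compounds alone.

Series notes. Compound 1 `Cc1c(O)ccc2cc(-n3cc(-c4ccccc4)nn3)c(=O)oc12` gives 25200 nM in a functional assay on MCF7 cells (Homo sapiens) for antiproliferative activity; on this read-out lower numbers stand for stronger inhibition and higher numbers for weaker inhibition. Compound 2 `CC(=O)Oc1ccc2cc(-n3cc(-c4ccccc4)nn3)c(=O)oc2c1C` gives 40800 nM in this assay; the step of a 1.6-fold higher number from compound 1 to compound 2 (0.21 log units; within the scatter) is acetyl in place of hydrogen on an oxygen on an aromatic ring. Compound 3 `CO[C@@H]1[C@@H](O)[C@@H](O)[C@H](Oc2ccc3c(c2C)OC(=O)C(n2cc(-c4ccc(F)cc4F)nn2)C3)OC1(C)C` sits at a limit of this assay rather than at a number, > 100000 nM, which is the limit of > 100000 nM in this assay, at which 1 of the 3 values shown sits. Among the two numbers, compound 2 stands highest, with compound 1 nearest and within the scatter of it.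

Compound 4 `COc1ccc(-c2cn(-c3cc4ccc(OC(C)=O)c(C)c4oc3=O)nn2)cc1` differs from compound 2 by methoxy in place of hydrogen on an aromatic carbon, that is, phenyl to 4-methoxyphenyl. Among the compounds with values here, none of the measured steps touches this six-membered aromatic ring of carbon only; the single measured step concerns acetyl in place of hydrogen on an oxygen on an aromatic ring and stays within the scatter. The series thus offers no measured change at this place to read from, and no step beyond the scatter is expected, so the step of a 1.0-fold lower number from compound 2 to compound 4 (0.01 log units; within the scatter) is estimated as essentially flat. Compound 4 is expected at 40000 nM in this assay, within 15000 nM to 110000 nM.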

Compound 4, half-maximal inhibitory concentration: > 100000 nM
Compound 4: only a limit was reported (the forecaster's own chance of this, stated with the estimate: 25%); at least 2.5-fold (0.39 log units) between middle value and limit.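

In this assay, the change from phenyl to 4-methoxyphenyl gives an at least 2.4-fold higher number from compound 2 to compound 4 (0.38 log units; beyond the scatter), which makes this six-membered aromatic ring of carbon the first place in the series where a single change moves the read-out beyond the scatter. As far as these compounds go, compound 4 gives > 100000 nM, which is a limit and not a number, so the step has a lower bound only and its full size remains unknown. With this one added methoxy, the number of values at the limit rises to two: the limit of > 100000 nM in this assay, at which 2 of the 4 values shown sit.

From the compounds shown here alone, it remains open whether an amine or a carboxylic acid in the same place would weaken inhibition as methoxy does, or whether the effect is specific to methoxy. Going by these compounds, it is also open whether methoxy would produce a similar step on compound 1, which carries the free hydroxyl in place of the acetyl ester.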